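This account rests on a few compounds, and the source may have more. Where it says the series, first, only, none or still open, it means among the compounds named here.

Compound 1 `N#Cc1ccc(N2CCC(C(=O)N3N=CC[C@H]3c3cc(F)cc(F)c3)CC2)nn1`, compound 2 `O=C(C1CCN(c2ccncn2)CC1)N1N=CC[C@H]1c1ccccc1` and compound 3 `C[C@@H]1C=NN(C(=O)C(C)(C)C)[C@@H]1c1ccccc1` have each been measured in a physicochemical assay for lipophilicity, read by HPLC, measured as chromatographic lipophilicity, at pH 7.4; a higher number here means a more lipophilic compound, a lower number a more polar compound. In this assay compound 1 gives 4.8. Compound 2 gives 3.2 in this assay, the lowest of the three numbers: compound 1 is its nearest neighbour, standing higher by a gap beyond the scatter, and compound 3 is furthest from it, higher by a gap also beyond the scatter. In this assay compound 3 gives 6.5.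

Compound 4 `O=C(c1cscn1)N1CCC(C(=O)N2N=CC[C@H]2c2ccccc2)CC1` has not yet been measured in this assay. It is reached from compound 2 by a single change: (1,3-thiazol-4-yl)carbonyl in place of pyrimidin-4-yl on an amine nitrogen in a ring. Within the data shown here, no pair of measured compounds differs in just one place, so there is no measured step of this kind to lean on; the expectation rests on the change alone. An amide carbonyl now sits on the amine nitrogen in the ring where an aromatic ring stood before, and the thiazole brings one more hydrogen-bond acceptor than the pyrimidine it replaces. The step of a number 0.40 log units lower from compound 2 to compound 4 (beyond the scatter) is expected to be small and downward, near the edge of the scatter. Compound 4 is therefore estimated at 2.8 in this assay, with an expected range from 2.2 to 3.4.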

Compound 4, distribution coefficient: 3
Beside the measured number, compound 4's estimate is 0.20 log units below it; measured number inside the range.
By their numbers in this assay, from the lowest: compounds 4 and 2 (each within the scatter of the next); then compound 1; then compound 3.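

Among these compounds, at the amine nitrogen in a ring, the only step read at this position so far in this assay is a number 0.20 log units lower from compound 2 to compound 4 (within the scatter), so pyrimidin-4-yl and (1,3-thiazol-4-yl)carbonyl cannot be told apart here. The earlier compounds shown here, none of which differed in just one place, could not show this: a six-membered aromatic ring attached directly to the nitrogen can give way to a five-membered aromatic ring attached through a carbonyl without a step beyond the scatter. Nothing measured here accounts for this outcome, which stands as an observation only.

This single step says nothing about whether other groups on the same nitrogen, such as a simple alkyl chain, a carboxylic acid or an amine-bearing side chain, would stay as close to compound 2 in this assay. It also leaves open whether the same exchange on the core of compound 1 would give a step of similar size, and how far the result carries beyond this pair of aromatic rings.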